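Swapping Methyl for Bromo in a Kallikrein-7 Inhibitor Series

A few compounds are considered here, and "the series" means these few. Any claim that something is new, unique, unknown or untested is made for them only; others in the source may bear on it.

Within the data shown here, compound 2 `CC1=NC(c2cn(S(=O)(=O)c3ccccc3C)c3ccc(C)cc23)CN1` gives 1000 nM in an assay on isolated protein for inhibition of kallikrein-7 (Homo sapiens), read by fluorescence, with stated times of 10 min and 30 min (a higher number here means a weaker inhibitor, a lower number a stronger inhibitor), the lower of the two numbers measured so far; compound 1 `CC1=NC(c2cn(S(=O)(=O)c3ccccc3F)c3ccc(C)cc23)CN1` gives 4100 nM. Among the measured compounds shown here, the one measured step, a 4.1-fold lower number from compound 1 to compound 2 (0.61 log units; beyond the scatter), shows that changing the group at this position of the shared core can move the number beyond the scatter. Compound 3 `CC1=NC(c2cn(S(=O)(=O)c3ccccc3Br)c3ccc(C)cc23)CN1` carries the change (bromo in place of methyl on an aromatic carbon), turning 2-methylphenyl into 2-bromophenyl. For the measured compounds named here, that single step bears on it only loosely, as no bromo analogue has yet been measured. Compound 3 is therefore expected to give 800 nM, within 250 nM to 2500 nM. The expected step is a 1.3-fold lower number from compound 2 to compound 3 (0.10 log units; within the scatter), which need not exceed the scatter.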

Compound 3, half-maximal inhibitory concentration: 390 nM
Estimate against measurement, compound 3: 2.1-fold (0.31 log units) above; the measured number falls inside the stated range.
By their numbers in this assay, from the lowest: compound 3; then compound 2; then compound 1.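

In this assay, this place on the aromatic ring, ortho to a large group, proves more responsive than the first pair suggested: bromo in place of methyl gives a 2.6-fold lower number from compound 2 to compound 3 (0.41 log units; beyond the scatter), and bromo in place of fluoro gives an 11-fold lower number from compound 1 to compound 3 (1.02 log units; beyond the scatter). With every step among the three beyond the scatter, the order fluoro, methyl, bromo is clear, and compound 3 is the strongest inhibitor of the three. Nothing available accounts for this order. Going by these compounds, whether chloro, iodo, methoxy or an amine here would extend the order remains open.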